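The source may hold more compounds than are shown below. What is called first, only, known or untested is meant among the compounds shown, and "the series" means these compounds.

Measured so far:
compound 1 `CS/C(=N\C(=O)c1csc([N+](=O)[O-])c1)NC(=O)c1csc([N+](=O)[O-])c1`, 56900 nM
compound 2 `O=C(/N=C(/NC(=O)c1csc([N+](=O)[O-])c1)[Se]Cc1ccccc1)c1csc([N+](=O)[O-])c1`, 23500 nM

In a functional assay on K562 cells (Homo sapiens) for cytotoxicity, read by MTT assay, with a stated time of 72 h (on this read-out lower numbers stand for stronger inhibition of growth and higher numbers for weaker inhibition of growth), compound 2 holds the lower of the two numbers, the step of a 2.4-fold lower number from compound 1 to compound 2 (0.38 log units; beyond the scatter) running beyond the scatter. Compound 3 `C[Se]/C(=N\C(=O)c1csc([N+](=O)[O-])c1)NC(=O)c1csc([N+](=O)[O-])c1` differs from compound 2 by hydrogen in place of phenyl on a saturated chain carbon bound to a selenium atom, so it keeps the selenium of compound 2 but carries the methyl of compound 1. Within the data shown here, the only measured step, a 2.4-fold lower number from compound 1 to compound 2 (0.38 log units; beyond the scatter), changes the chalcogen and the benzyl together, so its two parts cannot be separated. Removing the phenyl is expected to return part of that step: compound 3 is expected to give 40000 nM in this assay, within 15000 nM to 100000 nM, a step of a 1.7-fold higher number from compound 2 to compound 3 (0.23 log units; within the scatter).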

Compound 3, concentration for 50% growth inhibition: 4980 nM
Beside the measured number, compound 3's estimate is 8.0-fold (0.90 log units) above it, and the stated range ends above it.
By their numbers in this assay, from the lowest: compound 3; then compound 2; then compound 1.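

In this assay, with selenium held, benzyl to methyl gives a 4.7-fold lower number from compound 2 to compound 3 (0.67 log units; beyond the scatter), so the phenyl does not carry the earlier gain and its removal strengthens growth inhibition. Among these compounds, with methyl held, selenium in place of sulfur gives an 11-fold lower number from compound 1 to compound 3 (1.06 log units; beyond the scatter), the first reading of that exchange alone, and a larger step than the mixed one seen earlier. Nothing available gives a cause for either step. Open, as far as these compounds go, is whether an ethyl or longer chain on selenium keeps this level of inhibition, and whether benzyl on sulfur would lose ground as benzyl on selenium does.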